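A few compounds are considered here, and "the series" means these few. Any claim that something is new, unique, unknown or untested is made for them only; others in the source may bear on it.

Compound 1 `O=C(CNC(=O)c1ccc(-c2ccccc2)cc1)N/N=C/c1ccccc1OCc1ccccc1Cl` reads > 50000 nM in a functional assay on HepG2 cells (Homo sapiens) for inhibition, read by MTT assay, with a stated time of 24 h (on this read-out higher numbers stand for weaker inhibition and lower numbers for stronger inhibition), which is a limit and not a number. Going by the values given here, compound 2 `O=C(CNC(=O)c1cccnc1Cl)N/N=C/c1ccccc1OCc1ccccc1Cl` gives 16900 nM, the only true number so far. Compound 3 `O=C(CNC(=O)c1ccc(F)cc1)N/N=C/c1ccccc1OCc1ccccc1Cl` brings 4-fluorophenyl in place of 2-chloropyridin-3-yl on a carbonyl carbon. Among the compounds with values here, the one measured step at this carbonyl carbon is an at least 2.9-fold lower number from compound 1 to compound 2 (0.47 log units; beyond the scatter), and its true size stays open. Within the data shown here, with only that step as a guide, a small rise in this assay towards weaker inhibition, within the scatter, is expected: a 1.5-fold higher number from compound 2 to compound 3 (0.17 log units; within the scatter). Compound 3 is estimated at 25000 nM, with an expected range of 9000 nM to 60000 nM.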

Compound 3, half-maximal inhibitory concentration: 24900 nM
For compound 3 the middle estimate is 1.0-fold (0.00 log units) above the measured one; measured number inside the range.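

In this assay, 4-fluorophenyl on this carbonyl carbon reads much like 2-chloropyridin-3-yl, with a 1.5-fold higher number from compound 2 to compound 3 (0.17 log units; within the scatter), so the ring nitrogen and the chlorine are not required for a reading in this range. A second step away from the larger group is now available, with an at least 2.0-fold lower number from compound 1 to compound 3 (0.30 log units; that floor lies within the scatter). The true size of that step stays open because it starts from a limit and not a number: the limit of > 50000 nM in this assay, at which 1 of the 3 values shown sits.

Still open, from the compounds shown here alone, is how an amine or a carboxylic acid in place of the aromatic ring on this carbonyl carbon would read.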